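Phenethyl added to the ring amine of compound 3

A few compounds are considered here, and "the series" means these few. Any claim that something is new, unique, unknown or untested is made for them only; others in the source may bear on it.

Compound 1 `COc1ccc2nccc(C3CN(C4CCN(Cc5cc6ccccc6[nH]5)C4)C(=O)O3)c2c1`: < 50200 nM
Compound 2 `COc1ccc2nccc(C3CN(C4CCN(Cc5ccc6ccccc6c5)CC4)C(=O)O3)c2c1`: 1260 nM
Compound 3 `COc1ccc2nccc(C3CN(C4CCN(C)CC4)C(=O)O3)c2c1`: < 50200 nM

In an in vitro functional assay on RBL cells for antagonist activity at C-C chemokine receptor type 8 (Homo sapiens), read by FLIPR and calcium flux (on this read-out lower numbers stand for stronger inhibition and higher numbers for weaker inhibition), compound 2 gives 1260 nM. For compound 3 only a limit of the assay is reported, < 50200 nM. Compound 1 likewise stands at a limit, < 50200 nM. Within the data shown here, the single step between measured compounds, a step that the limit leaves unreadable from compound 2 to compound 3, cannot be sized because the limit of < 50200 nM in this assay, at which 2 of the 3 values shown sit, hides the true value of compound 3.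

Compound 4 `COc1ccc2nccc(C3CN(C4CCN(CCCc5ccccc5)CC4)C(=O)O3)c2c1` differs from compound 3 by phenethyl in place of hydrogen on a saturated chain carbon bound to an amine nitrogen in a ring. With no readable step to lean on, the expectation rests on compound 2, which carries an aromatic group on the same chain carbon and gives 1260 nM. Compound 4 is therefore expected near 5000 nM, within 1000 nM to 30000 nM, an estimated step that the limit leaves unreadable from compound 3 to compound 4 toward stronger inhibition.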

Compound 4, half-maximal inhibitory concentration: 251 nM
Compound 4: the middle estimate sits 20-fold (1.30 log units) above what was measured; the measured number lies below the stated range.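

In this assay, the position on the saturated chain carbon bound to an amine nitrogen in a ring proves sensitive to which aromatic group it carries: phenethyl in place of naphthalen-2-yl gives a 5.0-fold lower number from compound 2 to compound 4 (0.70 log units; beyond the scatter). A single six-membered aromatic ring of carbon only is therefore enough here, and the larger naphthalen-2-yl is not needed for a measurable value. The steps from compound 3 cannot be read because of this limit: the limit of < 50200 nM in this assay, at which 2 of the 4 values shown sit.

As far as these compounds go, whether a longer chain would lower the number further stays open. So does whether an amine or a carboxylic acid in place of phenethyl would keep the inhibition.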